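Benzyloxy variant of a compound sitting at the cytotoxicity limit

A few compounds are considered here, and "the series" means these few. Any claim that something is new, unique, unknown or untested is made for them only; others in the source may bear on it.

Of the compounds shown here, three sharing one core have been tested in an ADME assay on HFF cells (Homo sapiens) for cytotoxicity, with a stated time of 8 days; on this read-out higher numbers stand for lower toxicity in this test and lower numbers for higher toxicity in this test. Compound 1 `CCCCSc1nc(N)nc2c1ncn2/C=C1/CC1(CO)CO` carries a butylsulfanyl group, compound 2 `Nc1nc(NC2CCCCC2)c2ncn(/C=C3/CC3(CO)CO)c2n1` a cyclohexylamino group, and compound 3 `CSc1nc(N)nc2c1ncn2/C=C1/CC1(CO)CO` a methylsulfanyl group. In this assay compound 1 gives > 300000 nM, which is a limit of the assay rather than a number. Compound 2 likewise gives > 300000 nM, again a limit. Compound 3 gives > 300000 nM, also a limit. Compound 3 therefore stands at the same limit as the other two, as shown by the limit of > 300000 nM in this assay, at which 3 of the 3 values shown sit. The steps a step that the two limits leave unreadable from compound 1 to compound 2, a step that the two limits leave unreadable from compound 1 to compound 3 and a step that the two limits leave unreadable from compound 2 to compound 3 are all unreadable: every end sits at the limit. Compound 4 `Nc1nc(OCc2ccccc2)c2ncn(/C=C3/CC3(CO)CO)c2n1` is not yet measured; it differs from compound 3 by benzyloxy in place of methylsulfanyl on an aromatic carbon. For the measured compounds named here, no measured step bears on this change; the three limits are the only guide. Compound 4 is expected to show a step of a number no higher from compound 3 to compound 4 (the limit leaves the size open) and to sit at the limit once more. The estimated value for compound 4 is 300000 nM, with a range from 100000 nM to 1000000 nM.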

Compound 4, half-maximal cytotoxic concentration: > 300000 nM
Compound 4: a limit, no number; the forecaster's own chance of this, stated with the estimate: 80%; the middle value sits exactly at the limit.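

Compound 4 sits at the same limit as compound 1, compound 2 and compound 3, so no step among these four compounds can be read in this assay: the limit of > 300000 nM in this assay, at which 4 of the 4 values shown sit.

The compounds shown leave open whether the butylsulfanyl, cyclohexylamino, methylsulfanyl and benzyloxy groups differ at all in toxicity to these cells.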